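The source may report more compounds than this note shows. Statements on the series, on what has been measured and on what is new or still open speak of the compounds shown alone.

Measured so far in a functional assay on A549 cells (Homo sapiens) for cytotoxicity; on this read-out higher numbers stand for weaker inhibition and lower numbers for stronger inhibition:
- compound 1 `COc1c(O)cc2c3c1C[C@@H](C)C[C@H](OC)[C@H](O3)[C@@H](C)/C=C(\C)[C@H](OC(N)=O)[C@@H](OC)C[C@@H](O)/C=C(\C)C(=O)N2`: > 100000 nM (a limit)
- compound 2 `COc1c(O)cc2c3c1C[C@@H](C)C[C@H](OC)[C@H](O3)[C@@H](C)/C=C(\C)[C@H](OC(N)=O)[C@@H](OC)/C=C\C=C(/C)C(=O)N2`: 16000 nM

The entry for compound 1 is a limit of the assay and not a number. For the measured compounds named here, compound 2, at 16000 nM, holds the only numerical value so far, so it has no measured neighbour to be ranked against.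

Next is compound 3 `COc1c(O)cc2c3c1C[C@@H](C)C[C@H](OC)[C@H](O3)[C@@H](C)/C=C(\C)[C@H](OC(N)=O)[C@@H](OC)/C=C\C=C(\C)C(=O)N2`, an isomer of compound 2: the two compounds have the same atoms and bonds and differ only in configuration as drawn: 1 of 9 stereo elements differ; a double bond is drawn E in compound 2 and Z in compound 3. Going by the values given here, no measured step shows what a change of double-bond geometry does in this assay. No shift beyond the scatter is therefore expected, and no direction can be assigned with confidence. The estimated 1.3-fold lower number from compound 2 to compound 3 (0.12 log units; within the scatter) is small and stays within the scatter. For compound 3 the estimated value is 12000 nM, with an expected range of 2500 nM to 60000 nM.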

Compound 3, half-maximal inhibitory concentration: 13000 nM
Compound 3: the middle estimate sits 1.1-fold (0.03 log units) below what was measured; the measured number falls inside the stated range.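

In this assay, for the compounds shown here, the first readable step is a 1.2-fold lower number from compound 2 to compound 3 (0.09 log units; within the scatter). This step reads the double-bond geometry alone, because nothing else separates the pair: the fact that compounds 2 and 3 differ only in the configuration as drawn. On these two compounds, the change from E to Z at this double bond therefore leaves the number within the scatter.

Compound 1 gives > 100000 nM, which is a limit of the assay and not a number, so steps to it cannot be read. Open, from the compounds shown here alone, is whether an amine or a carboxylic acid on the shared core would shift the number in this assay beyond the scatter, and whether the same geometry change would stay within the scatter on a core carrying such a group.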